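From benzoyl to acetyl in a cytotoxic series

The compounds below may be only part of what the source reports. "The series", "measured", "known", "first", "only" and "open" are said of these compounds alone.

In a functional assay on HeLa cells (Homo sapiens) for cytotoxicity, read by resazurin assay, with a stated time of 72 h (a higher number here means a weaker inhibitor, a lower number a stronger inhibitor), compound 1 (`CCSC(=S)SCC(=O)c1ccc(NS(=O)(=O)c2ccccc2)cc1`) gives 9040 nM and compound 2 (`CCSC(=S)SCC(=O)c1cccc(NC(=O)c2ccccc2)c1`) gives 8230 nM while compound 3 (`COc1ccc(C(=O)CSC(=S)SCCNC(C)=O)cc1`) gives 11100 nM as its number. Compound 2 therefore stands level with the other two, its value lying within the scatter of both.

Compound 4 (`CCSC(=S)SCC(=O)c1cccc(NC(C)=O)c1`) departs from compound 2 in one place: methyl in place of phenyl on a carbonyl carbon, or benzoyl to acetyl (methyl in place of phenyl on a carbonyl carbon). Within the data shown here, no measured pair shows this change, so the data give no direct size for it in this assay and any forecast rests on indirect evidence. Compound 3 also carries an acetyl group on an amide nitrogen and gives 11100 nM as its number, so a slight move toward a higher number is expected, with nothing beyond the scatter. The estimated step of a 1.5-fold higher number from compound 2 to compound 4 (0.16 log units; within the scatter) is thus expected to stay small. Compound 4 is estimated at 12000 nM with 6000 nM and 24000 nM as the ends of the expected range.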

Compound 4, half-maximal inhibitory concentration: 9380 nM
For compound 4 the middle estimate is 1.3-fold (0.11 log units) above the measured one, and the stated range covers the measured number.
By their numbers in this assay, from the lowest: compounds 2, 1, 4 and 3 (each within the scatter of the next).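

In this assay, among these compounds, the one pair that differs in a single place gives a 1.1-fold higher number from compound 2 to compound 4 (0.06 log units; within the scatter), with benzoyl going to acetyl. The earlier compounds shown here differed in several places at once and could not isolate this group, whereas this pair shows that the phenyl on the carbonyl carbon, with its 6 heavy atoms and its ring, can give way to methyl, with 1 heavy atom and no ring, without a step beyond the scatter. Nothing on hand explains why the two compounds read alike.

As far as these compounds go, it remains open whether a longer chain, such as butyl, or a trifluoromethyl group on the same carbonyl carbon would also stay within the scatter. Also open, from the compounds shown here alone, is what a free amine would give in place of the whole amide.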